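Trading Chlorine for Methyl on a Weak Binder

The source may report more compounds than this note shows. Statements on the series, on what has been measured and on what is new or still open speak of the compounds shown alone.

Compound 1 `CN(CCCn1c(=O)oc2ccccc21)Cc1ccc(Cl)cc1` has the highest number of the two compounds measured in an assay on membranes from liver for displacement of a labelled ligand from Sigma non-opioid intracellular receptor 1 (Rattus norvegicus), read by scintillation counting; a lower number here means a stronger inhibitor, a higher number a weaker inhibitor. In this assay compound 1 gives 1150 nM, whereas compound 2 `CN(CCCCn1c(=O)oc2ccccc21)Cc1ccccc1` gives 2.6 nM, a gap that lies well beyond the scatter. The two structures differ at more than one point, however, and the data do not separate those points, so the gap cannot be tied to any single change.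

Compound 3 `Cc1cccc(CN(C)CCCn2c(=O)oc3ccccc32)c1` keeps the chain and the core of compound 1 and carries one change: 3-methylphenyl in place of 4-chlorophenyl on a saturated chain carbon bound to an amine nitrogen. Among the measured compounds shown here, no measured pair isolates this change, so its effect is uncertain. For the change from compound 1 to compound 3, a modest step toward a lower number is expected, a 1.9-fold lower number from compound 1 to compound 3 (0.28 log units; within the scatter), which may well fall within the scatter. Compound 3 is therefore estimated to give about 600 nM in this assay, within a range from 150 nM to 2500 nM.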

Compound 3, inhibition constant: 1840 nM
Compound 3: the middle estimate sits 3.1-fold (0.49 log units) below what was measured; the range from low to high includes it.
By their numbers in this assay, from the lowest: compound 2; then compounds 1 and 3 (each within the scatter of the next).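

Placing 3-methylphenyl in place of 4-chlorophenyl on a saturated chain carbon bound to an amine nitrogen gives a 1.6-fold higher number from compound 1 to compound 3 (0.20 log units; within the scatter) in this assay, the first measured pair that isolates one change at this position. Compound 1 and compound 3 therefore cannot be ranked, and this exchange of one substituted phenyl group for another leaves the reading within the scatter, so compound 3 remains in the same range as compound 1. No supporting evidence bears on this result.

On these data alone, whether the position would respond to a different kind of group, such as an amine or a carboxylic acid on the phenyl ring, remains open. Also unresolved is how much of the large gap between compound 1 and compound 2 belongs to the chain and how much to the phenyl group, which would take a compound changed in only one of those places.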